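Chloro in place of fluoro on compound 3

The source may hold more compounds than are shown below. What is called first, only, known or untested is meant among the compounds shown, and "the series" means these compounds.

In a functional assay on MCF7 cells (Homo sapiens) for antiproliferative activity, read by MTT assay, with a stated time of 48 h (a lower number here means a stronger inhibitor, a higher number a weaker inhibitor), compound 1 (`O=C(/C=C/c1ccc(O)cc1)Nc1cc2c(Nc3ccc(Cl)c(Cl)c3)ncnc2s1`) gives 60600 nM as its reading, compound 2 (`COc1ccc(/C=C/C(=O)Nc2cc3c(Nc4ccc(Cl)c(Cl)c4)ncnc3s2)cc1`) gives 20100 nM and compound 3 (`O=C(/C=C/c1ccccc1)Nc1cc2c(Nc3ccc(F)c(Cl)c3)ncnc2s1`) gives 14300 nM on the same scale. Compound 3 thus sits within the scatter of compound 2 and, beyond the scatter, has a lower number than compound 1. Compound 4 (`O=C(/C=C/c1ccccc1)Nc1cc2c(Nc3ccc(Cl)c(Cl)c3)ncnc2s1`) is still unmeasured. It departs from compound 3 by a single exchange: chloro in place of fluoro on an aromatic carbon (chloro in place of fluoro on an aromatic carbon, turning 3-chloro-4-fluorophenyl into 3,4-dichlorophenyl).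

Among the measured compounds shown here, the only measured step is a 3.0-fold lower number from compound 1 to compound 2 (0.48 log units; beyond the scatter) and it concerns methyl in place of hydrogen on an oxygen on an aromatic ring, so it does not speak to this exchange. For the measured compounds named here, no measured pair isolates fluoro against chloro. Compound 1 and compound 2 do carry the 3,4-dichlorophenyl group, but both also differ from compound 4 in a second place, and their two readings lie beyond the scatter of each other. No step beyond the scatter is therefore expected in this assay in either direction. The expected step is a 1.2-fold higher number from compound 3 to compound 4 (0.08 log units; within the scatter) and it stays within the scatter. For compound 4 the estimated value is 17000 nM with an expected range from 7000 nM to 42000 nM across repeat measurements.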

Compound 4, half-maximal inhibitory concentration: 15300 nM
The estimate for compound 4 lay 1.1-fold (0.05 log units) above the measured number; the measured number falls inside the stated range.
By their numbers in this assay, from the lowest: compounds 3, 4 and 2 (each within the scatter of the next); then compound 1.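

In this assay, among the compounds shown here, chloro in place of fluoro on this aromatic carbon gives a 1.1-fold higher number from compound 3 to compound 4 (0.03 log units; within the scatter) and so provides the first direct comparison of the two halogens here, which this assay does not separate. With the 3,4-dichlorophenyl group held constant, compound 4 also supplies an unsubstituted reference for the other aromatic ring: hydrogen in place of methoxy gives a 1.3-fold lower number from compound 2 to compound 4 (0.12 log units; within the scatter), whereas hydrogen in place of hydroxy gives a 4.0-fold lower number from compound 1 to compound 4 (0.60 log units; beyond the scatter), so among these three compounds the hydroxy compound alone stands apart, while the methoxy and unsubstituted compounds remain within the scatter of each other. Nothing available explains why the halogen exchange leaves the reading within the scatter or why the hydroxy compound stands apart.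

Only fluoro and chloro are shown on this carbon, which leaves open how bromo, methyl or an amine would read there. Hydroxy and methoxy appear only alongside the 3,4-dichlorophenyl group, so it also remains open whether their steps would carry over to compounds bearing the 3-chloro-4-fluorophenyl group.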